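The source may report more compounds than this note shows. Statements on the series, on what has been measured and on what is new or still open speak of the compounds shown alone.

Working notes on the series. Compound 1 `CC(=O)Nc1cn2cc(-c3cc(NC(=O)c4ccc(CN5CCN(C)CC5)c(C(F)(F)F)c4)ccc3C)ccc2n1` and compound 2 `CC(=O)Nc1cn2cc(-c3cc(NC(=O)c4cccc(Cl)c4)ccc3C)ccc2n1` share one core and are both characterised in a functional assay on A-375 cells (Homo sapiens) for antiproliferative activity; on this read-out lower numbers stand for an effect already at smaller amounts and higher numbers for an effect only at larger amounts of compound. In this assay compound 1 gives 430 nM, and in this assay compound 2 gives 70 nM. Of the two numbers that of compound 2 is the lowest; compound 1 stands at a higher number, and the gap between the two lies beyond the scatter. Within the data shown here, no single-change pair among the measured compounds is available, so no measured step can be quoted.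

The next compound, compound 3 `CC(=O)Nc1cn2cc(-c3cc(NC(=O)c4cccc(C(F)(F)F)c4)ccc3C)ccc2n1`, is compound 2 with one change: trifluoromethyl in place of chloro on an aromatic carbon. Among the measured compounds shown here, nothing measured so far isolates this change, and compound 1 carries further differences, so its number cannot be read as a guide. Within this series the change is expected to leave the result close to that of compound 2, with a step from compound 2 to compound 3 of a 1.1-fold lower number from compound 2 to compound 3 (0.03 log units; within the scatter) in this assay, none beyond the scatter. Compound 3 is therefore estimated at 65 nM in this assay, with a range from 20 nM to 200 nM.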

Compound 3, half-maximal effective concentration: 86 nM
Beside the measured number, compound 3's estimate is 1.3-fold (0.12 log units) below it; measured number inside the range.
By their numbers in this assay, from the lowest: compounds 2 and 3 (each within the scatter of the next); then compound 1.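

In this assay, trifluoromethyl in place of chloro on the aromatic carbon gives a 1.2-fold higher number from compound 2 to compound 3 (0.09 log units; within the scatter), so this read-out does not separate the two groups at this position, even though trifluoromethyl brings 4 heavy atoms where chloro brings 1. Compound 3 also provides the first single-change link to compound 1: hydrogen in place of (4-methylpiperazin-1-yl)methyl on an aromatic carbon gives a 5.0-fold lower number from compound 1 to compound 3 (0.70 log units; beyond the scatter), a modest step beyond the scatter, with trifluoromethyl present on both sides of the comparison. No measured property of these groups is available to account for either step.

The compounds shown span only chloro and trifluoromethyl at this position, so it remains open whether a group of another kind there, such as an amine, a carboxylic acid or a nitrile, would stay in the same range of numbers. On these data alone, it also remains open whether the step seen on removing (4-methylpiperazin-1-yl)methyl would recur with chloro in place of trifluoromethyl, and whether a smaller amine such as dimethylaminomethyl at that place would give a number closer to compound 3 or to compound 1.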